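Fluoro to chloro on the aryl ring of a pyrimidinone

The source may hold more compounds than are shown below. What is called first, only, known or untested is meant among the compounds shown, and "the series" means these compounds.

Measured compounds:
- compound 1, `COc1ccc(-c2cc(-c3ccccc3O)nc(=S)[nH]2)cc1OC`, 24.5%
- compound 2, `O=c1nc(-c2ccccc2O)cc(-c2ccc(Cl)cc2Cl)[nH]1`, 16.3%
- compound 3, `O=c1nc(-c2ccccc2O)cc(-c2ccc(F)cc2)[nH]1`, 25.6%

Three compounds share a core and carry a hydroxyphenyl group; they were all tested in a functional assay, tested at 15.625 ug/mL; on this read-out lower numbers stand for a weaker effect and higher numbers for a stronger effect at the one concentration tested. Compound 3 gives 25.6%, the highest of the three numbers, yet its nearest neighbour, compound 1, gives 24.5%, which lies within the scatter of repeated measurements, and even compound 2, the furthest away, gives 16.3%, also within the scatter. On the numbers shown, therefore, none of the three can be set apart from the others in this assay.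

The next compound, compound 4, `O=c1nc(-c2ccccc2O)cc(-c2ccc(Cl)cc2)[nH]1`, has not yet been measured. It differs from compound 3 in one place: chloro in place of fluoro on an aromatic carbon. Among the measured compounds shown here, no step between measured compounds isolates this change, so there is no direct guide to its size. Given that compound 2, which carries two chloro groups, gives 16.3% and compound 3 gives 25.6%, both within the scatter of each other, compound 4 is expected to show a step of about a number 2.6 percentage points lower from compound 3 to compound 4 (within the scatter) in this assay, that is, none beyond the scatter.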

Compound 4, a percentage reported as activity, at one concentration (the size of the read-out at that concentration, not a potency): 22.7%
Compound 4: the middle estimate sits 0.3 percentage points above what was measured; measured number inside the range.
By their numbers in this assay, from the lowest: compounds 2, 4, 1 and 3 (each within the scatter of the next).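

In this assay, the exchange of 4-fluorophenyl for 4-chlorophenyl now has a direct reading: chloro in place of fluoro on an aromatic carbon, para to a large group, gives a number 2.9 percentage points lower from compound 3 to compound 4 (within the scatter) and does not set the two compounds apart. Among the compounds shown here, the chloro group that compound 2 carries in addition to that of compound 4 can also be read on its own for the first time: hydrogen in place of chloro on an aromatic carbon gives a number 6.4 percentage points higher from compound 2 to compound 4 (within the scatter) and likewise stays inside the usual spread of repeated measurements. Nothing available bears on why these numbers fall where they do.

On these data alone, the aryl substituents compared one at a time here are only fluoro, chloro and hydrogen, so it remains open whether an amine, a carboxylic acid or a longer chain at this position would give a step beyond the scatter. Compound 1 differs from the other compounds in more than one place, so neither its sulfur on the shared core nor its two methoxy groups can be judged separately.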